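This account rests on a few compounds, and the source may have more. Where it says the series, first, only, none or still open, it means among the compounds named here.

Measured so far in a physicochemical assay for solubility, read by HPLC, using the shake flask method, measured as kinetic solubility, with a stated time of 2 h, at pH 7.4; a lower number here means a less soluble compound, a higher number a more soluble compound:
Compound 1 `Cc1cc(NCc2ccccn2)n2ncc(-c3ccc(N(C)C)cc3)c2n1` gives < 5000 nM, a limit of the assay rather than a number.
Compound 2 `Cc1cc(NCc2ccccn2)n2ncc(-c3ccc(C(F)(F)F)cc3)c2n1` gives < 5000 nM, likewise a limit rather than a number.

Going by the values given here, compound 1 thus stands at the lower edge of what this assay reports: its solubility is known only as a limit, and the one further value shown, that of compound 2, is a limit as well. Among the compounds with values here, the single measured change, trifluoromethyl in place of dimethylamino on an aromatic carbon, gives a step that the two limits leave unreadable from compound 1 to compound 2, and its size cannot be read because both values sit at the limit described by the limit of < 5000 nM in this assay, at which 2 of the 2 values shown sit.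

Compound 3 `Cc1cc(NCc2ccccn2)n2ncc(-c3ccccc3F)c2n1` has not yet been measured in this assay. It differs from compound 1 by 2-fluorophenyl in place of 4-(dimethylamino)phenyl on an aromatic carbon. Within the data shown here, the only measured step that bears on this change is the unreadable one from compound 1 to compound 2, so there is nothing to point to a rise in solubility, and a value again at the limit is expected. For compound 3 the estimate in this assay is 3000 nM, with an expected range from 500 nM to 8000 nM. The expected step from compound 1 to compound 3 is accordingly a step that the limit leaves unreadable from compound 1 to compound 3, most likely again reported only as a limit.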

Compound 3, solubility: 5000 nM
Compound 3: middle estimate off by 1.7-fold (0.22 log units), on the low side; the measured number falls inside the stated range.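

In this assay, compound 3 gives 5000 nM, the only actual number among the compounds shown. Compound 1 gives < 5000 nM, which is a limit of the assay and not a number. As far as these compounds go, on an aromatic carbon of the five-membered aromatic ring, 2-fluorophenyl in place of 4-(dimethylamino)phenyl therefore gives a number no lower from compound 1 to compound 3 (the limit leaves the size open), so this position can carry a group that yields a readable value, but the size of the change remains unknown because compound 1 sits at the assay's limit, as do most of the values here: the limit of < 5000 nM in this assay, at which 2 of the 3 values shown sit.

The compounds shown leave open whether the readable value of compound 3 depends on the fluorine itself or simply on the absence of the dimethylamino group, a question that a plain phenyl group at the same place could help to settle. They also leave open how this assay would respond to a phenyl group carrying a carboxylic acid or a morpholine, and whether any such compound would give a number clearly beyond that of compound 3.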